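The compounds below may be only part of what the source reports. "The series", "measured", "known", "first", "only" and "open" are said of these compounds alone.

Going by the values given here, compound 2 `COc1cc2c(Oc3ccc(NC(=O)N/N=C/c4cccs4)cc3F)ccnc2cc1OCCCN1CCCCC1` is the analogue with the lower number of the two measured so far in a functional assay on MKN-45 cells (Homo sapiens) for cytotoxicity, read by MTT assay, with a stated time of 72 h; a lower number here means a stronger inhibitor, a higher number a weaker inhibitor: compound 2 gives 740 nM, while compound 1 `COc1cc2c(Oc3ccc(NC(=O)N/N=C/c4ccncc4)cc3F)ccnc2cc1OCCCN1CCCCC1` gives 980 nM, a gap of a 1.3-fold lower number from compound 1 to compound 2 (0.12 log units; within the scatter). Compound 3 `COc1cc2c(Oc3ccc(NC(=S)N/N=C/c4ccccc4)cc3F)ccnc2cc1OCCCN1CCCCC1` differs from compound 2 by a group of 11 heavy atoms (8 carbon, 2 nitrogen, 1 sulfur; one six-membered aromatic ring of carbon only) in place of a group of 10 heavy atoms (6 carbon, 2 nitrogen, 1 oxygen, 1 sulfur; one five-membered aromatic ring with 1 hetero atom), on a nitrogen on an aromatic ring. Among the compounds with values here, no measured step covers this change; the one step at hand, from compound 1 to compound 2 a 1.3-fold lower number from compound 1 to compound 2 (0.12 log units; within the scatter), only shows that swapping the aromatic ring there stayed within the scatter. Compound 3 is therefore expected near compound 2, at 650 nM, between 250 nM and 1700 nM, a step of a 1.1-fold lower number from compound 2 to compound 3 (0.06 log units; within the scatter).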

Compound 3, half-maximal inhibitory concentration: 710 nM
Compound 3: middle estimate off by 1.1-fold (0.04 log units), on the low side; measured number inside the range.
By their numbers in this assay, from the lowest: compounds 3, 2 and 1 (each within the scatter of the next).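

In this assay, the change on the nitrogen on an aromatic ring now goes beyond the aromatic ring alone: the entering group has a six-membered aromatic ring of carbon only and no oxygen, yet the step is a 1.0-fold lower number from compound 2 to compound 3 (0.02 log units; within the scatter) and, against the pyridine-bearing group, a 1.4-fold lower number from compound 1 to compound 3 (0.14 log units; within the scatter). This position therefore tolerated both replacements without leaving the scatter. The data offer no explanation for this. The compounds shown do not separate the ring swap from the loss of oxygen, and whether an amine or a carboxylic acid on the aromatic ring would move the number beyond the scatter remains open.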